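Naphthalene in place of biphenyl on the sulfonamide

This account rests on a few compounds, and the source may have more. Where it says the series, first, only, none or still open, it means among the compounds named here.

Compound 2 `Cc1ccc(NS(=O)(=O)c2ccc(-c3ccccc3)cc2)cc1Nc1nccc(-c2cccnc2)n1` was tested in a functional assay on K562 cells (Homo sapiens) for cytotoxicity, read by MTT assay, with a stated time of 24 h (on this read-out lower numbers stand for stronger inhibition and higher numbers for weaker inhibition), where compound 2 gives 9490 nM. Going by the values given here, of the two numbers measured so far it is the lower, but its nearest neighbour, compound 1 `Cc1ccc(NS(=O)(=O)c2ccc(Cl)cc2)cc1Nc1nccc(-c2cccnc2)n1`, gives 10200 nM in this assay, and the step from compound 1 to compound 2 a 1.1-fold lower number from compound 1 to compound 2 (0.03 log units; within the scatter) lies within the scatter. That step exchanged chloro for phenyl on the aryl sulfonyl group, and it did not move the number.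

Compound 3 `Cc1ccc(NS(=O)(=O)c2ccc3ccccc3c2)cc1Nc1nccc(-c2cccnc2)n1` is the next variation at the same place: naphthalen-2-yl in place of 4-phenylphenyl on a sulfonyl sulfur. Among the compounds with values here, the only measured step that bears on it is the one from compound 1 to compound 2, which changed the same aryl sulfonyl substituent and stayed within the scatter. Compound 3 is therefore expected to differ from compound 2 by a 1.0-fold higher number from compound 2 to compound 3 (0.00 log units; within the scatter), that is, by no more than the scatter. Compound 3 is estimated at 9500 nM, within 4500 nM to 20000 nM.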

Compound 3, half-maximal inhibitory concentration: 9890 nM
The estimate for compound 3 lay 1.0-fold (0.02 log units) below the measured number; low and high end bracket the measured number.
By their numbers in this assay, from the lowest: compounds 2, 3 and 1 (each within the scatter of the next).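

In this assay, replacing 4-phenylphenyl with naphthalen-2-yl on the sulfonyl sulfur gives a 1.0-fold higher number from compound 2 to compound 3 (0.02 log units; within the scatter), and replacing 4-chlorophenyl with the same group gives a 1.0-fold lower number from compound 1 to compound 3 (0.01 log units; within the scatter). With a third aryl group in place, the number at this position still does not move beyond the scatter, and the change in ring arrangement from 4-phenylphenyl to naphthalen-2-yl has no readable effect on it. Nothing available explains why the number stays so flat at this position.

On these data alone, all three compounds carry an aryl group on the sulfonyl sulfur, so it remains open whether an amine, a carboxylic acid or a longer alkyl chain there would shift the number beyond the scatter. As far as these compounds go, the shared core is the same in all three, so the effect of changes elsewhere on it also remains open.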